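The source may hold more compounds than are shown below. What is called first, only, known or untested is meant among the compounds shown, and "the series" means these compounds.

In this series the compounds share one core and differ only in what the ring amine nitrogen carries. Compound 1 `CC(C)(C)OC(=O)CN1CCc2c(sc(NC(=O)Nc3ccc(Cl)cc3)c2C(N)=O)C1` bears a tert-butoxycarbonyl on a saturated chain carbon bound to that amine nitrogen in a ring. In a functional assay (strain AB) with Danio rerio as the target, read by microscopy, with a stated time of 1 h (on this read-out lower numbers stand for an effect already at smaller amounts and higher numbers for an effect only at larger amounts of compound), compound 1 reaches only a limit, > 25000 nM, and no number. Compound 2 `CCN1CCc2c(sc(NC(=O)Nc3ccc(Cl)cc3)c2C(N)=O)C1` has methyl in place of tert-butoxycarbonyl at the same position, and in this assay compound 2 gives 3120 nM. Among the compounds with values here, the step of an at least 8.0-fold lower number from compound 1 to compound 2 (0.90 log units; beyond the scatter) is the one measured change here, and it is bounded by the limit of > 25000 nM in this assay, at which 1 of the 2 values shown sits. Compound 2 therefore stands as the only actual number shown; the other value is a limit.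

Compound 3 `COCCCN1CCc2c(sc(NC(=O)Nc3ccc(Cl)cc3)c2C(N)=O)C1` differs from compound 2 by methoxymethyl in place of hydrogen on a saturated chain carbon, two bonds along the chain from an amine nitrogen in a ring. Within the data shown here, the single measured step bears on this only loosely: it also altered the chain on the ring amine nitrogen, but it removed a tert-butoxycarbonyl, whereas compound 3 merely extends ethyl to 3-methoxypropyl. A step of the earlier size is not expected; the step of a 1.1-fold higher number from compound 2 to compound 3 (0.05 log units; within the scatter) is expected to remain within the scatter. Compound 3 is accordingly estimated at 3500 nM, between 1200 nM and 10000 nM.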

Compound 3, half-maximal effective concentration: 2400 nM
Compound 3: the middle estimate sits 1.5-fold (0.16 log units) above what was measured; measured number inside the range.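

Methoxymethyl in place of hydrogen on a saturated chain carbon, two bonds along the chain from an amine nitrogen in a ring, gives a 1.3-fold lower number from compound 2 to compound 3 (0.11 log units; within the scatter) in this assay, so the chain on the ring amine nitrogen can carry this added methoxymethyl without a change that stands out from the scatter. With 2-methoxyethyl in place of tert-butoxycarbonyl, the result is an at least 10-fold lower number from compound 1 to compound 3 (1.01 log units; beyond the scatter), so the gap from the tert-butoxycarbonyl compound now appears with two different chains rather than with ethyl alone. Compound 1 has only a limit, so the true size of both steps from it remains unknown: the limit of > 25000 nM in this assay, at which 1 of the 3 values shown sits.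

The compounds shown leave open whether the oxygen in the 3-methoxypropyl chain matters at all, and a plain butyl chain would give the direct comparison. They also leave open whether a chain ending in a carboxylic acid or an amine would fall with compound 1 or with compound 2 and compound 3, and thus whether it is the tert-butoxycarbonyl itself that sets compound 1 apart.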